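The compounds below may be only part of what the source reports. "The series", "measured", "known", "first", "only" and "open" are said of these compounds alone.

In an ADME assay on MT4 cells (Homo sapiens) for cytotoxicity, read by MTT assay, with a stated time of 3 days (a lower number here means that less compound is tolerated, a higher number that more compound is tolerated), compound 1 `O=C(COC(=O)c1ccc([N+](=O)[O-])o1)NCC1CCCO1` gives > 100000 nM, which is a limit of the assay and not a number. Compound 2 `CC(C)(C)N(Cc1cccc([N+](=O)[O-])c1)C(=O)COC(=O)c1ccc([N+](=O)[O-])o1` gives > 100000 nM, again a limit. Compound 3 `CC(=O)Oc1ccccc1CN(C(=O)COC(=O)c1ccc([N+](=O)[O-])o1)C(C)(C)C` gives > 100000 nM, also a limit, so it stands without a number of its own.

Compound 4 `CC(C)(C)N(Cc1ccccc1C(F)(F)F)C(=O)COC(=O)c1ccc([N+](=O)[O-])o1` has not yet been measured. It departs from compound 3 by one change: trifluoromethyl in place of acetoxy on an aromatic carbon. This puts trifluoromethyl in place of acetoxy on an aromatic carbon, ortho to a large group.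

Among the compounds with values here, the one measured step that touches this part of the structure is a step that the two limits leave unreadable from compound 2 to compound 3, so it offers no size to carry over. The data amount to the limit of > 100000 nM in this assay, at which 3 of the 3 values shown sit. With no readable step to go on, no change beyond the scatter is expected in this assay. The expected step is a number no higher from compound 3 to compound 4 (the limit leaves the size open). Compound 4 is most likely to be reported as a limit too. For compound 4 the estimate is 100000 nM, with an expected range of 30000 nM to 200000 nM.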

Compound 4, half-maximal cytotoxic concentration: 95000 nM
Beside the measured number, compound 4's estimate is 1.1-fold (0.02 log units) above it; the range from low to high includes it.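

In this assay, within the data shown here, compound 4 gives 95000 nM, the first real number in this set. Compound 1, compound 2 and compound 3 each gave only a limit. Trifluoromethyl in place of acetoxy on this aromatic carbon gives an at least 1.0-fold lower number from compound 3 to compound 4 (0.02 log units; that floor lies within the scatter), and 2-(trifluoromethyl)phenyl in place of 3-nitrophenyl gives an at least 1.0-fold lower number from compound 2 to compound 4 (0.02 log units; that floor lies within the scatter), so neither change shows a shift that stands clear of the scatter. Most of the set still rests at one ceiling: the limit of > 100000 nM in this assay, at which 3 of the 4 values shown sit.

On these data alone, how far past their limits compound 2 and compound 3 lie stays open, so the true size of both steps cannot be told. Also open, as far as these compounds go, is whether an amine or a carboxylic acid on this aromatic carbon would give a clearly lower number in this assay.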